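From 2-chlorophenyl to thiophen-2-yl on a shared core

A few compounds are considered here, and "the series" means these few. Any claim that something is new, unique, unknown or untested is made for them only; others in the source may bear on it.

In a functional assay on Raji cells (Homo sapiens) for cytotoxicity, read by CCK-8 assay, with a stated time of 24 h (on this read-out lower numbers stand for stronger inhibition and higher numbers for weaker inhibition), compound 1 (`C=CC(=O)N1C(=O)CC(c2ccc(C)cc2)Sc2ccccc21`) gives 75500 nM while compound 2 (`C=CC(=O)N1C(=O)CC(c2ccc(Br)cc2)Sc2ccccc21`) gives 51300 nM and compound 3 (`C=CC(=O)N1C(=O)CC(c2ccccc2Cl)Sc2ccccc21`) gives 50400 nM on the same core. Compound 3 therefore stands level with compound 2 and within the scatter of compound 1, so the three values form a single group.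

Compound 4 (`C=CC(=O)N1C(=O)CC(c2cccs2)Sc2ccccc21`) carries thiophen-2-yl in place of 2-chlorophenyl on a saturated ring carbon next to the ring sulfur. Two measured exchanges at that same carbon bear most directly on this change, giving a 1.5-fold lower number from compound 1 to compound 3 (0.18 log units; within the scatter) and a 1.0-fold lower number from compound 2 to compound 3 (0.01 log units; within the scatter) as their results. The swap of bromo in place of methyl on an aromatic carbon adds a 1.5-fold lower number from compound 1 to compound 2 (0.17 log units; within the scatter) as a third comparison. None of these steps leaves the scatter, but none of them introduces a five-membered aromatic ring, so the evidence is indirect.

On these steps, no change beyond the scatter is expected in this assay and no direction is favoured. The estimated step is a 1.1-fold higher number from compound 3 to compound 4 (0.04 log units; within the scatter) for this exchange. Compound 4 is expected at 55000 nM with an estimated range of 28000 nM to 100000 nM for a repeated measurement.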

Compound 4, half-maximal inhibitory concentration: 659000 nM
Compound 4: the middle estimate sits 12-fold (1.08 log units) below what was measured; the measured number lies above the stated range.
By their numbers in this assay, from the lowest: compounds 3, 2 and 1 (each within the scatter of the next); then compound 4.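

In this assay, the saturated ring carbon of the shared core had looked indifferent to its substituent, since the 4-methylphenyl, 4-bromophenyl and 2-chlorophenyl compounds all lay within the scatter of one another. Thiophen-2-yl ends that picture, with a 13-fold higher number from compound 3 to compound 4 (1.12 log units; beyond the scatter) and a 13-fold higher number from compound 2 to compound 4 (1.11 log units; beyond the scatter) as the two large steps, while an 8.7-fold higher number from compound 1 to compound 4 (0.94 log units; beyond the scatter) is a modest step that also lies beyond the scatter. Compound 4 is therefore the weakest of the four compounds, and the position is shown to respond to its substituent after all, although this rests on the single compound that carries a five-membered aromatic ring there, with the three six-membered aromatic rings on the other side of the gap.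

The compounds shown leave open whether this drop belongs to thiophen-2-yl alone or would recur with furan-2-yl or thiophen-3-yl, and whether pyridin-2-yl, a six-membered aromatic ring with a ring nitrogen, would stay with the phenyl compounds or fall with compound 4. Nothing available here explains why the exchange has so large a result in this assay.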